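Swapping Naphthalene for Pyridine Under a Cytotoxicity Read-Out

A few compounds are considered here, and "the series" means these few. Any claim that something is new, unique, unknown or untested is made for them only; others in the source may bear on it.

Of the compounds shown here, two have so far been tested in an ADME assay on HEK293 cells (Homo sapiens) for cytotoxicity, read by CellTiter-Glo and resazurin assay, with a stated time of 72 h; on this read-out higher numbers stand for an effect only at larger amounts of compound and lower numbers for an effect already at smaller amounts. Compound 1 `CC(C)N(Cc1cccc(OCCCCCC(=O)O)c1)C(=O)c1ccc(-c2ccncc2)cc1` carries a pyridin-4-yl group and a free carboxylic acid at the end of its chain. In this assay compound 1 gives > 26000 nM, which is a limit of the assay rather than a number. Compound 2 `CCOC(=O)CCCCCOc1cccc(CN(C(=O)c2ccc(-c3ccc4ccccc4c3)cc2)C(C)C)c1` carries a naphthalen-2-yl group and an ethyl ester at the chain end. In this assay compound 2 gives > 26000 nM, again a limit of the assay and not a number. Compound 2 therefore stands where every value shown so far stands, at the limit of > 26000 nM in this assay, at which 2 of the 2 values shown sit.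

Compound 3 `CCOC(=O)CCCCCOc1cccc(CN(C(=O)c2ccc(-c3ccncc3)cc2)C(C)C)c1` has not yet been measured. It differs from compound 2 in one place: pyridin-4-yl in place of naphthalen-2-yl on an aromatic carbon. For the measured compounds named here, no step between two measured compounds is available, so the size of this change cannot be read from numbers already in hand. Both values sit at the limit, and no movement beyond the scatter is expected in this assay. The expected step is a step that the limit leaves unreadable from compound 2 to compound 3, that is, essentially no change. Compound 3 is thus estimated at 30000 nM, within a range from 20000 nM to 60000 nM, with the outcome most likely once more only a limit.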

Compound 3, half-maximal effective concentration: > 26000 nM
Compound 3: only a limit was reported; the forecaster's own chance of this, stated with the estimate: 85%; the middle value lies beyond the limit too.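

Neither the step from compound 2 to compound 3 nor the step from compound 1 to compound 3 can be read, since all three compounds share one result: the limit of > 26000 nM in this assay, at which 3 of the 3 values shown sit.

The compounds shown leave open at what concentration any of them would show an effect in this assay, and whether swapping naphthalen-2-yl for pyridin-4-yl or the ethyl ester for the free acid would matter there.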